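From methyl to acetamido in an antiproliferative series

The compounds below may be only part of what the source reports. "The series", "measured", "known", "first", "only" and "open" are said of these compounds alone.

compound 1 `COc1ccc(-c2c(Nc3ccc(NC(C)=O)cc3)c3ccc(OC)cc3oc2=O)cc1` gives 85800 nM
compound 2 `COc1ccc(-c2c(Nc3ccc(F)cc3)c3ccc(O)cc3oc2=O)cc1` gives 71500 nM
compound 3 `COc1ccc(-c2c(Nc3ccc(C)cc3)c3ccc(O)cc3oc2=O)cc1` gives 85500 nM

In a functional assay on MCF7 cells (Homo sapiens) for antiproliferative activity, read by MTT assay, with a stated time of 48 h (on this read-out higher numbers stand for weaker inhibition and lower numbers for stronger inhibition), compound 3 gives 85500 nM and lies within the usual scatter of both other compounds. Compound 4 `COc1ccc(-c2c(Nc3ccc(NC(C)=O)cc3)c3ccc(O)cc3oc2=O)cc1` follows from compound 3 by the change acetamido in place of methyl on an aromatic carbon in which acetamido takes the place of methyl on an aromatic carbon, para to a large group. Among the compounds with values here, the one measured step at this place is a 1.2-fold higher number from compound 2 to compound 3 (0.08 log units; within the scatter) for methyl in place of fluoro, and it stays within the scatter. That single exchange says little about a group as large as acetamido. Compound 1 carries the 4-acetamidophenyl group on its own core, and its value of 85800 nM stands close to that of compound 3. No step beyond the scatter is therefore expected in this assay for this exchange. The expected change is a 1.1-fold lower number from compound 3 to compound 4 (0.03 log units; within the scatter) and no more. Compound 4 is expected at 80000 nM within an estimated range of 40000 nM to 150000 nM in this assay.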

Compound 4, half-maximal inhibitory concentration: > 100000 nM
Compound 4: a limit, no number (the forecaster's own chance of this, stated with the estimate: 15%); middle value at least 1.2-fold (0.09 log units) from the limit.
By their numbers in this assay, from the lowest: compounds 2, 3 and 1 (each within the scatter of the next). At a limit, above all of these: compound 4.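

In this assay compound 4 gives > 100000 nM, a limit and not a number, and it alone of the compounds shown stands at that limit: the limit of > 100000 nM in this assay, at which 1 of the 4 values shown sits. Acetamido on this aromatic carbon brings no stronger inhibition, since the exchange for methyl gives an at least 1.1-fold higher number from compound 3 to compound 4 (0.06 log units; that floor lies within the scatter) and the exchange for fluoro gives an at least 1.3-fold higher number from compound 2 to compound 4 (0.14 log units; that floor lies within the scatter), and both are floors that do not by themselves leave the scatter. The same holds for hydrogen in place of methyl on the oxygen with acetamido kept, which gives an at least 1.1-fold higher number from compound 1 to compound 4 (0.06 log units; that floor lies within the scatter).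

On these data alone, how far compound 4 lies past its limit stays open, and with it the true size of all three steps. Also open, as far as these compounds go, is whether an amine or a carboxylic acid in this same place would give a number inside the range of this assay.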